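This account rests on a few compounds, and the source may have more. Where it says the series, first, only, none or still open, it means among the compounds named here.

Three measured compounds share one core and differ only in the aromatic group attached to it. Compound 1 `NC(=O)c1cccc(-c2cnc(C(=O)CCCCCCc3ccccc3)o2)c1` gives 6 nM in an assay (Rattus norvegicus) for inhibition of Fatty-acid amide hydrolase 1 (Homo sapiens); a higher number here means a weaker inhibitor, a lower number a stronger inhibitor. Compound 2 `N#Cc1cccc(-c2cnc(C(=O)CCCCCCc3ccccc3)o2)c1` gives 15 nM in this assay, and compound 3 `O=C(CCCCCCc1ccccc1)c1ncc(-c2ccc(F)cc2)o1` gives 62 nM. Compound 3 therefore has the highest number of the three, that is, it is the weakest inhibitor: the nearest is compound 2, and the step of a 4.1-fold higher number from compound 2 to compound 3 (0.62 log units; beyond the scatter); the furthest is compound 1, and the step of a 10-fold higher number from compound 1 to compound 3 (1.01 log units; beyond the scatter).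

Compound 4 `O=C(CCCCCCc1ccccc1)c1ncc(-c2ccc(C(=O)C(F)(F)F)cc2)o1` is not yet measured. It differs from compound 3 in one place: (trifluoromethyl)carbonyl in place of fluoro on an aromatic carbon. Among the measured compounds shown here, no measured pair changes the same group, so the step can only be judged by the pattern of its neighbours. Both substituted rings with a hydrogen-bond acceptor, in compound 1 and compound 2, gave lower numbers than the fluoro ring of compound 3, as the steps of a 10-fold higher number from compound 1 to compound 3 (1.01 log units; beyond the scatter) and a 4.1-fold higher number from compound 2 to compound 3 (0.62 log units; beyond the scatter) show, although they sit in a different place. A move in the same direction, towards a lower number, is expected for compound 4, of modest size, a 3.1-fold lower number from compound 3 to compound 4 (0.49 log units; beyond the scatter). Compound 4 is thus estimated at 20 nM, within a range from 5 nM to 80 nM.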

Compound 4, inhibition constant: 65 nM
For compound 4 the middle estimate is 3.3-fold (0.51 log units) below the measured one; the measured number falls inside the stated range.
By their numbers in this assay, from the lowest: compound 1; then compound 2; then compounds 3 and 4 (each within the scatter of the next).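

In this assay, replacing fluoro with (trifluoromethyl)carbonyl para to a large group gives a 1.0-fold higher number from compound 3 to compound 4 (0.02 log units; within the scatter), so five more heavy atoms and a hydrogen-bond acceptor at this position leave the reading unchanged within the scatter. Compound 4 therefore goes against the pattern suggested by compound 1 and compound 2: among the compounds shown, having a hydrogen-bond acceptor on this aromatic ring does not by itself go with a lower number than that of compound 3. Nothing available explains why these two different groups give readings so alike.

The compounds shown leave open whether the lower numbers of compound 1 and compound 2 belong to their carbamoyl and nitrile groups or to the different place those groups occupy, since neither group appears para to a large group and (trifluoromethyl)carbonyl appears nowhere else on the ring. From the compounds shown here alone, it also remains open whether a simple amine, a carboxylic acid or a longer carbon chain at this position would match compound 3 and compound 4 or shift the number in either direction.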